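Hydroxy in place of pyridin-3-yl: expected loss of affinity

A few compounds are considered here, and "the series" means these few. Any claim that something is new, unique, unknown or untested is made for them only; others in the source may bear on it.

Three compounds have numbers in an assay on cell membranes for binding affinity to Neuronal acetylcholine receptor; alpha4/beta2 (Rattus norvegicus), read by radioligand binding; on this read-out lower numbers stand for stronger inhibition and higher numbers for weaker inhibition. Compound 1 `CCOc1cncc(N2CCNCC2)c1` gives 500 nM. Compound 2 `Nc1cccc(-c2cncc(N3CCCNCC3)c2)c1` gives 4 nM. Compound 3 `c1cncc(-c2cncc(N3CCCNCC3)c2)c1` gives 2.8 nM. Compound 3 thus sits at the low end together with compound 2, the two within the usual scatter of each other, while compound 1, which differs from compound 3 in more than one place, lies far above both, beyond the scatter. Compound 4 `Oc1cncc(N2CCCNCC2)c1` is not yet measured in this assay. It differs from compound 3 by hydroxy in place of pyridin-3-yl on an aromatic carbon. Going by the values given here, no step between measured compounds isolates this change; compound 1 only shows that the analogue without a second aromatic ring gives a high number. A marked rise, beyond the scatter, is expected, a 110-fold higher number from compound 3 to compound 4 (2.03 log units; beyond the scatter). Compound 4 is estimated at 300 nM, between 40 nM and 2500 nM.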

Compound 4, half-maximal inhibitory concentration: 2.4 nM
Beside the measured number, compound 4's estimate is 130-fold (2.10 log units) above it, and the stated range ends above it.
By their numbers in this assay, from the lowest: compounds 4, 3 and 2 (each within the scatter of the next); then compound 1.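

In this assay hydroxy in place of pyridin-3-yl gives a 1.2-fold lower number from compound 3 to compound 4 (0.07 log units; within the scatter) on an aromatic carbon two atoms from the ring nitrogen. A second aromatic ring is thus not needed at this position for a low number: in compound 4 a single oxygen-bearing group takes the place of the six heavy atoms of pyridin-3-yl with no change beyond the scatter. Nothing at hand bears on why the two groups match. Still open, on these data alone, is whether a methoxy group, an amine or a carboxylic acid on the same carbon also keeps the number this low.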